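Methyl for Hydrogen: Expected Cytotoxicity of Compound 4

The source may report more compounds than this note shows. Statements on the series, on what has been measured and on what is new or still open speak of the compounds shown alone.

Compound 1 `Cc1ccc2cc(CN(Cc3ccc(C(C)(C)C)cc3)C3CCCC3)c(=O)[nH]c2c1`: in a toxicity assay on MDCK cells (Canis lupus familiaris) for cytotoxicity, read by crystal violet staining, with a stated time of 48 h (on this read-out higher numbers stand for lower toxicity in this test and lower numbers for higher toxicity in this test), compound 1 gives > 10000 nM, which is a limit of the assay.
Compound 2 `CCc1ccc2cc(CN(Cc3ccc(C(C)(C)C)cc3)C3CCCC3)c(=O)[nH]c2c1`: in this assay compound 2 gives > 9000 nM, also a limit of the assay.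
Compound 3 `Cc1ccc2[nH]c(=O)c(CN(Cc3ccc(C(C)(C)C)cc3)[C@H](C)c3ccc(F)cc3)cc2c1`: in this assay compound 3 gives > 5000 nM, again a limit of the assay.

Compound 2 differs from compound 1 by methyl in place of hydrogen on a saturated chain carbon bound to an aromatic carbon, and that change gave a step that the two limits leave unreadable from compound 1 to compound 2. Compound 4 `CCc1ccc2[nH]c(=O)c(CN(Cc3ccc(C(C)(C)C)cc3)[C@H](C)c3ccc(F)cc3)cc2c1` carries the same change relative to compound 3, namely (methyl in place of hydrogen on a saturated chain carbon bound to an aromatic carbon). The difference between the cores of compound 1 and compound 3 is not broken down here. Because a step that the two limits leave unreadable from compound 1 to compound 2 shows no readable effect of this change, the step expected from compound 3 to compound 4 is a step that the limit leaves unreadable from compound 3 to compound 4. Compound 4 is therefore estimated at 10000 nM in this assay, most likely reported again only as a limit.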

Compound 4, half-maximal cytotoxic concentration: > 5000 nM
Compound 4 was reported as a limit; the forecaster's own chance of this, stated with the estimate: 85%; the middle value is on the limit's open side.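

Compound 3 and compound 4 are both reported only as limits in this assay, and no step can be read between them. The compounds shown leave open where any true cytotoxic concentration lies, and whether methyl in place of hydrogen changes it.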